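Swapping iodo for thiophen-2-yl on an antiproliferative scaffold

The compounds below may be only part of what the source reports. "The series", "measured", "known", "first", "only" and "open" are said of these compounds alone.

The study starts from compound 1, `Cc1ncnc2c1c(I)cn2[C@@H]1O[C@H](CO)[C@@H](O)[C@H]1O`, which in a functional assay on HeLa S3 cells (Homo sapiens) for antiproliferative activity, read by XTT assay, with a stated time of 72 h (on this read-out higher numbers stand for weaker inhibition and lower numbers for stronger inhibition), gives 4080 nM. Among the values shown, compound 1 holds the only outright number; the one other value is a limit. That other value belongs to compound 2, `C#Cc1cn([C@@H]2O[C@H](CO)[C@@H](O)[C@H]2O)c2nc(C)nc(N)c12`, whose result in this assay is given as > 20000 nM, a limit of the assay rather than a number, as noted in the limit of > 20000 nM in this assay, at which 1 of the 2 values shown sits. Compound 2 also differs from compound 1 in more than one place, so the two values are set beside each other without any step being drawn between them.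

The account now turns to compound 3, `Cc1ncnc2c1c(-c1cccs1)cn2[C@@H]1O[C@H](CO)[C@@H](O)[C@H]1O`, which has not yet been measured in this assay. Relative to compound 1 it carries thiophen-2-yl in place of iodo on an aromatic carbon. Among the measured compounds shown here, no step between measured compounds is available to guide the expectation, so the estimate rests on compound 1 alone and on the nature of the change. The step from compound 1 to compound 3 is expected to be modest, a 2.0-fold lower number from compound 1 to compound 3 (0.31 log units; beyond the scatter), toward somewhat stronger inhibition but not far beyond the usual scatter. Compound 3 is therefore estimated at 2000 nM, within a range from 500 nM to 8000 nM.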

Compound 3, half-maximal inhibitory concentration: > 15000 nM
Compound 3 gave a limit, no number; the forecaster's own chance of this, stated with the estimate: 10%; middle value at least 7.5-fold (0.87 log units) away from the limit.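

On the core of compound 1, thiophen-2-yl in place of iodo on the aromatic carbon of the five-membered ring gives an at least 3.6-fold higher number from compound 1 to compound 3 (0.56 log units; beyond the scatter), a move toward weaker inhibition in this assay that lies beyond the usual scatter. The result for compound 3 is a limit of the assay and not a number: the limit of > 15000 nM in this assay, at which 1 of the 3 values shown sits. This is the first change in one place shown for this series, and it shows that the inhibition seen with iodo at this carbon does not survive the exchange for this five-membered aromatic ring, leaving compound 1 as the only compound here with an outright number.

What the compounds shown leave open is whether the loss belongs to thiophen-2-yl alone or would follow any ring at this carbon, as a phenyl ring or a furan-2-yl ring would test. Nor do they say how smaller groups on the same carbon, such as a methyl, a chloro or an amine, would compare with iodo in this assay, so the reach of this single step along the position stays unknown.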